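Moving the Amine Along the Chain in a Melanocortin Agonist

A few compounds are considered here, and "the series" means these few. Any claim that something is new, unique, unknown or untested is made for them only; others in the source may bear on it.

Compound 1: `CC(=O)N1C[C@@H](C(=O)N2CCN(c3ccc(C)cc3[C@@H](NC(=O)CCN(C)C)C(C)C)CC2)[C@H](c2ccc(Cl)cc2)C1` — 44 nM
Compound 2: `CNCC(=O)N[C@H](c1cc(C)ccc1N1CCN(C(=O)[C@@H]2CN(C3CCOCC3)C[C@H]2c2ccc(Cl)cc2)CC1)C(C)C` — 19 nM
Compound 3: `Cc1ccc(N2CCN(C(=O)[C@@H]3CN(C4CCOCC4)C[C@H]3c3ccc(Cl)cc3)CC2)c([C@@H](NC(=O)[C@H](C)N)C(C)C)c1` — 5.2 nM

These three compounds were tested in a functional assay on CHO cells for agonist activity at Melanocortin receptor 4 (Homo sapiens), read by cAMP accumulation; a lower number here means that less compound is needed, a higher number that more compound is needed for the effect. Compound 3 gives the lowest number of the three, with compound 2 nearest and compound 1 furthest away. Among the measured compounds shown here, the only single-point step among them, a 3.7-fold lower number from compound 2 to compound 3 (0.56 log units; beyond the scatter), came from swapping a (methylamino)methyl group for 1-aminoethyl on the carbonyl carbon.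

Compound 4, `Cc1ccc(N2CCN(C(=O)[C@@H]3CN(C4CCOCC4)C[C@H]3c3ccc(Cl)cc3)CC2)c([C@@H](NC(=O)CCN)C(C)C)c1`, differs from compound 3 by 2-aminoethyl in place of 1-aminoethyl on a carbonyl carbon; the amine thus moves one carbon further from the carbonyl and the stereocentre disappears. For the measured compounds named here, no measured step covers exactly this change, so only a loose expectation is possible. Since compound 3 sits at 5.2 nM and the chain rearrangement is small, compound 4 is expected to give a modestly higher number, a 1.9-fold higher number from compound 3 to compound 4 (0.28 log units; within the scatter), with an estimate of 10 nM (range 4 nM to 30 nM).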

Compound 4, half-maximal effective concentration: 6 nM
Compound 4: the middle estimate sits 1.7-fold (0.22 log units) above what was measured; the range from low to high includes it.
By their numbers in this assay, from the lowest: compounds 3 and 4 (each within the scatter of the next); then compound 2; then compound 1.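

Moving the amine one carbon along the chain, from 1-aminoethyl to 2-aminoethyl, also removes the defined stereocentre, yet a 1.2-fold higher number from compound 3 to compound 4 (0.06 log units; within the scatter) in this assay stays within the scatter. In these two compounds, neither the amine's place on this short chain nor that stereocentre separates the numbers. The methylamino arrangement of compound 2 does separate from the aminomethyl arrangement of compound 4, with a 3.2-fold lower number from compound 2 to compound 4 (0.50 log units; beyond the scatter) as the step, though no evidence here explains it.

Still open, going by these compounds, is how a longer chain such as 3-aminopropyl would read at this position. On these data alone, the mirror-image form of 1-aminoethyl is equally open.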